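Chloro for Methyl in a Collagen Promoter Inhibitor Series

The source may hold more compounds than are shown below. What is called first, only, known or untested is meant among the compounds shown, and "the series" means these compounds.

Compound 1, `Cc1ccc(-n2cc(C(=O)Nc3cc(F)cc(F)c3)c(=O)c3ccc(N(C)C)nc32)cc1OCCCCCCC[N+]12CCN(CC1)CC2`: 5.07%
Compound 2, `CN(C)c1ccc2c(=O)c(C(=O)Nc3cc(F)cc(F)c3)cn(-c3ccc(Cl)c(OCCCCCCC[N+]45CCN(CC4)CC5)c3)c2n1`: 8.08%
Compound 3, `CC[N+]1(CCCCCCCOc2ccc(-n3cc(C(=O)Nc4cc(F)cc(F)c4)c(=O)c4ccc(N(C)C)nc43)cc2C)CCCCC1`: 19.7%

All three were tested in an assay on LX2 cells for inhibition of COL1A1 promoter (Homo sapiens), read by a luciferase reporter, with a stated time of 24 h, tested at 20 uM; on this read-out higher numbers stand for a stronger effect at the one concentration tested and lower numbers for a weaker effect. Compound 1 and compound 2 share a core and differ in one place: chloro in place of methyl on an aromatic carbon. The step of a number 3 percentage points higher from compound 1 to compound 2 (within the scatter), so the two values cannot be told apart. Compound 3 carries a different core; the difference between the two cores is not broken down here. In this assay compound 3 gives 19.7%, the highest of the three numbers, and its steps to compound 2 and to compound 1 both lie beyond the scatter.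

Compound 4, `CC[N+]1(CCCCCCCOc2ccc(-n3cc(C(=O)Nc4cc(F)cc(F)c4)c(=O)c4ccc(N(C)C)nc43)cc2Cl)CCCCC1`, has not yet been measured. It differs from compound 3 in one place: chloro in place of methyl on an aromatic carbon. This is the same kind of change as that from compound 1 to compound 2, though the surroundings differ: in the earlier pair the place is para to a large group, here it is meta to a large group.

Within the data shown here, the only comparable step is a number 3 percentage points higher from compound 1 to compound 2 (within the scatter), a change within the scatter. The expectation for compound 4 is therefore a step of about a number 2.3 percentage points higher from compound 3 to compound 4 (within the scatter), resting on that earlier pair alone. In this assay compound 4 is estimated to give 22%, with a plausible range from 9% to 36%.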

Compound 4, a percentage reported as inhibition, at one concentration (the size of the read-out at that concentration, not a potency): 14.3%
The estimate for compound 4 lay 7.7 percentage points above the measured number, within the range that was stated.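

On the core of compound 3, chloro in place of methyl gives a number 5.4 percentage points lower from compound 3 to compound 4 (within the scatter) in this assay. Set beside the earlier pair, this step cannot be told apart from the one on the other core, so the change reads the same on both within the limits of the measurement: the same change on two cores in this assay, a number 3 percentage points higher (within the scatter) from compound 1 to compound 2 and a number 5.4 percentage points lower (within the scatter) from compound 3 to compound 4, 8.4 percentage points apart, within the scatter of two such steps. Among these compounds, this shows only that neither core gives a step beyond the scatter, and that the two pairs offer no sign of the core altering the outcome of this change; it does not show that the change is without effect in general, nor that the result would hold on a further core, since it rests on two pairs read at one concentration, which gives the size of an effect and not a potency.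

The compounds shown leave open how other groups on the same aromatic carbon, such as fluoro, bromo, methoxy or trifluoromethyl, would compare with methyl and chloro. They also leave open what a shorter or longer chain would do on either core, and how a neutral tertiary amine would compare at the end of that chain.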